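Dimethoxyphenyl Regiochemistry on a Dihydropyridine Thienoimidazole Series

A few compounds are considered here, and "the series" means these few. Any claim that something is new, unique, unknown or untested is made for them only; others in the source may bear on it.

Measured compounds:
compound 1 `CCOC(=O)C1=C(C)NC(C)=C(C(=O)OCC)C1c1c(-c2cc(OC)ccc2OC)nc2sc(C)cn12` gives 4810 nM
compound 2 `CCOC(=O)C1=C(C)NC(C)=C(C(=O)OCC)C1c1c(-c2cc(OC)ccc2OC)nc2sc(Br)cn12` gives 120 nM

In an ADME assay on Right cardiac atrium (Cavia porcellus) (on this read-out lower numbers stand for an effect already at smaller amounts and higher numbers for an effect only at larger amounts of compound), compound 2 stands lowest of the two numbers; its nearest neighbour is compound 1, at a number higher by a 40-fold lower number from compound 1 to compound 2 (1.60 log units; beyond the scatter), a change brought about by bromo in place of methyl on an aromatic carbon. Compound 3 `CCOC(=O)C1=C(C)NC(C)=C(C(=O)OCC)C1c1c(-c2cc(OC)cc(OC)c2)nc2sc(Br)cn12` is not yet measured. It differs from compound 2 by 3,5-dimethoxyphenyl in place of 2,5-dimethoxyphenyl on an aromatic carbon. Among the compounds with values here, no measured step touches this part of the molecule: the single known step concerns the bromo for methyl exchange and says nothing about how the methoxy arrangement on the phenyl ring affects this assay. With no guidance either way, compound 3 is expected to stay near compound 2, with the step of a 2.1-fold higher number from compound 2 to compound 3 (0.32 log units; beyond the scatter) expected to lie within the scatter, though with wide uncertainty. The estimate for compound 3 is 250 nM, ranging from 60 nM to 1500 nM.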

Compound 3, half-maximal effective concentration: 640 nM
For compound 3 the middle estimate is 2.6-fold (0.41 log units) below the measured one; measured number inside the range.
By their numbers in this assay, from the lowest: compound 2; then compound 3; then compound 1.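

In this assay, the place that carries the dimethoxyphenyl group responds to the arrangement of the methoxy groups alone: 3,5-dimethoxyphenyl in place of 2,5-dimethoxyphenyl gives a 5.3-fold higher number from compound 2 to compound 3 (0.73 log units; beyond the scatter), although the groups leaving and entering have the same atoms and the same counts. This part of the molecule therefore also bears on the read-out, a modest step beside the large one seen on exchanging methyl for bromo, a 40-fold lower number from compound 1 to compound 2 (1.60 log units; beyond the scatter). Nothing at hand explains why the arrangement matters.

From the compounds shown here alone, whether the same shift would hold with methyl in place of bromo remains open, as the two changes have been seen only separately. Also open, going by these compounds, is how a single methoxy, a hydroxyl or an amine on the phenyl ring would read here.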